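A chloro swap on the benzyl group of compound 3

The source may report more compounds than this note shows. Statements on the series, on what has been measured and on what is new or still open speak of the compounds shown alone.

Compound 1 `CCCOc1c(OC)c(OC)cc2c1C(=O)[C@]1(OC)C=C[C@H]2N(C(=O)OCC)N1C(=O)OCC` gives > 300 ug/mL as a limit, not a number
Compound 2 `COC(=O)N1[C@@H]2C=C[C@@](OC)(C(=O)c3c2cc(OC)c(OC)c3OCc2ccc(Cl)cc2)N1C(=O)OC` gives 55.9 ug/mL
Compound 3 `COc1ccc(COc2c(OC)c(OC)cc3c2C(=O)[C@]2(OC)C=C[C@H]3N(C(=O)OCC(C)C)N2C(=O)OCC(C)C)cc1` gives 47.9 ug/mL

All three results come from an ADME assay on KB cells (Homo sapiens) for cytotoxicity (a lower number here means that less compound is needed, a higher number that more compound is needed for the effect), where a smaller number marks a compound that takes effect at a lower concentration. Compound 3 has a measured number, and it lies within the usual scatter of the number for compound 2, so the two cannot be told apart here. The result for compound 1 is a limit of the assay.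

The next compound is compound 4 `COc1cc2c(c(OCc3ccc(Cl)cc3)c1OC)C(=O)[C@]1(OC)C=C[C@H]2N(C(=O)OCC(C)C)N1C(=O)OCC(C)C`. It keeps compound 3 unchanged except for one group: chloro in place of methoxy on an aromatic carbon. In other words, a 4-methoxybenzyl becomes a 4-chlorobenzyl, with chloro in place of methoxy on an aromatic carbon.

Going by the values given here, no measured pair of compounds differs in this one place alone, so the size of this step has not been seen directly. Compound 2 also carries a 4-chlorobenzyl and gives 55.9 ug/mL, which is within the scatter of the number for compound 3. On that limited basis, no shift beyond the scatter is expected in this assay, in either direction.

The expected 1.1-fold lower number from compound 3 to compound 4 (0.03 log units; within the scatter) is therefore small. For compound 4 the estimated value is 45 ug/mL, with an expected range from 20 ug/mL to 100 ug/mL.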

Compound 4, concentration for half-maximal effect: 42 ug/mL
Compound 4: the middle estimate sits 1.1-fold (0.03 log units) above what was measured; the measured number falls inside the stated range.
By their numbers in this assay, from the lowest: compounds 4, 3 and 2 (each within the scatter of the next). At a limit, above all of these: compound 1.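

This is the first pair among the compounds shown that differs in one place alone, so the swap of a 4-methoxybenzyl for a 4-chlorobenzyl can now be read directly: in this assay it gives a 1.1-fold lower number from compound 3 to compound 4 (0.06 log units; within the scatter) and so no shift that can be told apart from ordinary assay noise. At this place, on an aromatic carbon para to a large group, a methoxy with two heavy atoms and one hydrogen-bond acceptor gives way to a chloro with one heavy atom and no hydrogen-bond acceptor, and the two numbers still cannot be separated. Nothing among the data shown bears on why this exchange leaves the reading where it is.

The compounds shown leave open whether a different group at this place, such as an amine, a carboxylic acid or a longer chain, would move the number beyond the scatter. They also leave open whether the same swap would read alike with the carbamate groups carried by compound 1 or compound 2 in place of those shared by compound 3 and compound 4.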